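The source may hold more compounds than are shown below. What is called first, only, known or untested is meant among the compounds shown, and "the series" means these compounds.

Measured compounds:
- Compound 1, `COc1ccc(Nc2nc(SCc3cn(CC(=O)NC(=O)Nc4ccccn4)nn3)nc(-c3ccc(C(C)C)cc3)c2C#N)cc1`: in a functional assay on MGC-803 cells (Homo sapiens) for inhibition, read by MTT assay, with a stated time of 72 h (on this read-out lower numbers stand for stronger inhibition and higher numbers for weaker inhibition), compound 1 gives > 64000 nM, which is a limit of the assay and not a number.
- Compound 2, `Cc1ccc(Nc2nc(SCc3cn(CC(=O)NC(=O)Nc4ccccn4)nn3)nc(-c3ccc(C(C)C)cc3)c2C#N)cc1`: compound 2 gives 3360 nM.
- Compound 3, `Cc1cccc(Nc2nc(SCc3cn(CC(=O)NC(=O)Nc4ccccn4)nn3)nc(-c3ccc(C(C)C)cc3)c2C#N)c1`: compound 3 gives 25300 nM.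

Compound 3 therefore stands highest of the two numbers in this assay; the nearest value is that of compound 2, and the step reads a 7.5-fold higher number from compound 2 to compound 3 (0.88 log units; beyond the scatter). Compound 4, `COc1ccccc1Nc1nc(SCc2cn(CC(=O)NC(=O)Nc3ccccn3)nn2)nc(-c2ccc(C(C)C)cc2)c1C#N`, differs from compound 3 in one place: 2-methoxyphenyl in place of 3-methylphenyl on a nitrogen on an aromatic ring. Within the data shown here, two measured steps bear on this. The step of an at least 19-fold lower number from compound 1 to compound 2 (1.27 log units; beyond the scatter) shows that methyl in place of methoxy on an aromatic carbon lowered the number strongly, so the 4-methoxyphenyl compound 1 sits at the limit (the limit of > 64000 nM in this assay, at which 1 of the 3 values shown sits). The step of an at least 2.5-fold lower number from compound 1 to compound 3 (0.40 log units; beyond the scatter) shows the 3-methylphenyl compound 3 also below that limit. Compound 4 reintroduces a methoxy group, though as 2-methoxyphenyl, a position not yet measured here. On that basis compound 4 is expected to show a higher number than compound 3, a step of a 1.6-fold higher number from compound 3 to compound 4 (0.20 log units; within the scatter), with a real chance of reaching the limit. The estimate for compound 4 is 40000 nM, within the range 12000 nM to 130000 nM.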

Compound 4, half-maximal inhibitory concentration: > 64000 nM
Compound 4 gave a limit, no number (the forecaster's own chance of this, stated with the estimate: 35%); middle value at least 1.6-fold (0.20 log units) away from the limit.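

Placing the 2-methoxyphenyl group on this nitrogen raises the number in this assay, with an at least 2.5-fold higher number from compound 3 to compound 4 (0.40 log units; beyond the scatter) and an at least 19-fold higher number from compound 2 to compound 4 (1.27 log units; beyond the scatter). The step between compound 1 and compound 4 cannot be read, so the two methoxyphenyl compounds cannot be placed in order. Compound 1 and compound 4, the 4-methoxyphenyl and 2-methoxyphenyl compounds, both give a limit and not a number, whereas compound 2 and compound 3, with their methylphenyl groups, do not: the limit of > 64000 nM in this assay, at which 2 of the 4 values shown sit.

The compounds shown leave open how a 2-methylphenyl, a 3-methoxyphenyl or an unsubstituted phenyl group on this nitrogen would read. They also leave open whether a hydroxyl group or an amine in place of the methoxy group would bring the number back within the range of the assay.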